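The source may report more compounds than this note shows. Statements on the series, on what has been measured and on what is new or still open speak of the compounds shown alone.

Measured in a functional assay on HepG2 cells (Homo sapiens) for antiproliferative activity, read by spectrophotometry, with a stated time of 2 days; a higher number here means a weaker inhibitor of growth, a lower number a stronger inhibitor of growth:
Compound 1 `COc1ccc(C(F)(F)F)cc1Nc1ncc(C(F)(F)F)c(N2Cc3cccc(N(C)S(C)(=O)=O)c3C2)n1` gives > 30000 nM as a limit of the assay, not a number
Compound 2 `CN(c1cccc2c1CN(c1nc(Nc3cccc(Oc4ccccc4)c3)ncc1C(F)(F)F)C2)S(C)(=O)=O` gives 23000 nM
Compound 3 `CN(c1cccc2c1CN(c1nc(Nc3cc(C(F)(F)F)cc(C(F)(F)F)c3)ncc1C(F)(F)F)C2)S(C)(=O)=O` gives 10300 nM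

On the numbers shown, compound 1 stands at the limit of > 30000 nM in this assay, at which 1 of the 3 values shown sits, and so has no exact place in the series.

Compound 4 `Cc1cc(C)cc(Nc2ncc(C(F)(F)F)c(N3Cc4cccc(N(C)S(C)(=O)=O)c4C3)n2)c1` is not yet measured. Relative to compound 1 it carries 3,5-dimethylphenyl in place of 2-methoxy-5-(trifluoromethyl)phenyl on a nitrogen on an aromatic ring. Within the data shown here, no step between measured compounds is available to size this change. Among the measured compounds shown here, the only guides are compound 2 (23000 nM) and compound 3 (10300 nM), which share the core of compound 1.

A shift toward stronger growth inhibition in this assay is expected, with compound 4 landing near those two values, though it may also return only a limit. The expected size is an at least 2.0-fold lower number from compound 1 to compound 4 (0.30 log units; that floor lies within the scatter) on this estimate. The estimate for compound 4 is 15000 nM with an expected range of 6000 nM to 35000 nM as a working figure.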

Compound 4, concentration for 50% growth inhibition: > 30000 nM
Compound 4: only a limit was reported (the forecaster's own chance of this, stated with the estimate: 30%); middle value at least 2.0-fold (0.30 log units) from the limit.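

In this assay, compound 1 and compound 4 are each reported only as a limit of the assay, not a number, so no step between them can be read: the limit of > 30000 nM in this assay, at which 2 of the 4 values shown sit.

Still open, on these data alone, is how far 3,5-dimethylphenyl and 2-methoxy-5-(trifluoromethyl)phenyl on this nitrogen differ in growth inhibition in this assay.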